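The source may report more compounds than this note shows. Statements on the series, on what has been measured and on what is new or still open speak of the compounds shown alone.

Measured in a functional assay on SW 1116 cells (Homo sapiens) for antiproliferative activity, read by MTT assay, with a stated time of 24 h; a higher number here means a weaker inhibitor, a lower number a stronger inhibitor:
- compound 1 `Cc1ccc(CSc2nnc(-c3ccc4c(c3)OCCO4)n2-c2ccccc2)cc1`: 16200 nM
- compound 2 `Fc1cccc(F)c1CSc1nnc(-c2ccc3c(c2)OCCO3)n1-c1ccccc1`: 9010 nM

Compound 2 gives 9010 nM. Only compound 1 stands beside it, and the two values lie within the scatter of each other, so compound 2 holds no clear rank in this pair.

Compound 3 `Brc1ccccc1CSc1nnc(-c2ccc3c(c2)OCCO3)n1-c1ccccc1` has not yet been measured. Its difference from compound 2 is 2-bromophenyl in place of 2,6-difluorophenyl on a saturated chain carbon bound to a sulfur.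

For the measured compounds named here, one measured step bears on this place: a 1.8-fold lower number from compound 1 to compound 2 (0.25 log units; within the scatter). That exchange of 4-methylphenyl for 2,6-difluorophenyl stayed within the scatter. Going by the values given here, no measured compound carries 2-bromophenyl, so the evidence is thin and favours neither direction. On this single step, no change beyond the scatter is expected in this assay.

The expected step is a 1.2-fold higher number from compound 2 to compound 3 (0.09 log units; within the scatter). Compound 3 is estimated at 11000 nM, with an expected range of 4500 nM to 26000 nM.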

Compound 3, half-maximal inhibitory concentration: 7350 nM
Estimate against measurement, compound 3: 1.5-fold (0.18 log units) above, and the stated range covers the measured number.
By their numbers in this assay, from the lowest: compounds 3, 2 and 1 (each within the scatter of the next, the first and the last beyond it).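

In this assay, 2-bromophenyl in place of 2,6-difluorophenyl on a saturated chain carbon bound to a sulfur gives a 1.2-fold lower number from compound 2 to compound 3 (0.09 log units; within the scatter) and so does not separate these two groups at this position. For the compounds shown here, the new information lies in the comparison with 4-methylphenyl: 2-bromophenyl in its place gives a 2.2-fold lower number from compound 1 to compound 3 (0.34 log units; beyond the scatter), the first step beyond the scatter, though a modest one, whereas the exchange of 4-methylphenyl for 2,6-difluorophenyl gives a 1.8-fold lower number from compound 1 to compound 2 (0.25 log units; within the scatter) and does not clear it, so the aryl group at this place can shift the number, but only compound 3 separates from compound 1. No measurement bears on why 2-bromophenyl separates from 4-methylphenyl here.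

The compounds shown leave open whether a group of another kind on the phenyl ring, such as an amine or a carboxylic acid, would move the number further than the halogen-bearing groups do. Also open, on these data alone, is whether a longer chain between the sulfur and the aryl group would keep, lose or extend the modest step seen with 2-bromophenyl.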